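Removing one methoxy from the shared core

A few compounds are considered here, and "the series" means these few. Any claim that something is new, unique, unknown or untested is made for them only; others in the source may bear on it.

Compound 1 `COc1ccc(C(=O)/C=C\Nc2ccc(-c3nc4cc(OC)c(OC)c(OC)c4s3)cc2)cc1F` and compound 2 `COc1cc(C(=O)/C=C\Nc2ccc(-c3nc4cc(OC)c(OC)c(OC)c4s3)cc2)cc([N+](=O)[O-])c1OC` share a core; how the two cores differ is not broken down here. In a functional assay on A549 cells (Homo sapiens) for antiproliferative activity, read by sulforhodamine B assay, with a stated time of 48 h (a lower number here means a stronger inhibitor, a higher number a weaker inhibitor), compound 1 gives 15500 nM, and compound 2 gives 11800 nM, two numbers within the usual scatter of each other. Compound 3 `COc1cc(OC)c2sc(-c3ccc(N/C=C\C(=O)c4ccc(OC)c(F)c4)cc3)nc2c1` differs from compound 1 by hydrogen in place of methoxy on an aromatic carbon, and in this assay compound 3 gives 5300 nM, so that a 2.9-fold lower number from compound 1 to compound 3 (0.47 log units; beyond the scatter). Compound 4 `COc1cc(OC)c2sc(-c3ccc(N/C=C\C(=O)c4cc(OC)c(OC)c([N+](=O)[O-])c4)cc3)nc2c1` differs from compound 2 by hydrogen in place of methoxy on an aromatic carbon, the same change at the same place. Compound 4 has not yet been measured in this assay. Among the measured compounds shown here, because the one earlier instance of this change gave a 2.9-fold lower number from compound 1 to compound 3 (0.47 log units; beyond the scatter), a step of similar size is expected from compound 2, and compound 4 is estimated at 4200 nM, with a range from 1600 nM to 11000 nM. This estimate for compound 4 means an expected 2.8-fold lower number from compound 2 to compound 4 (0.45 log units; beyond the scatter).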

Compound 4, half-maximal inhibitory concentration: 13000 nM
The estimate for compound 4 lay 3.1-fold (0.49 log units) below the measured number; the measured number lies above the stated range.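

In this assay, the removal of the methoxy gives a 1.1-fold higher number from compound 2 to compound 4 (0.04 log units; within the scatter), so the change does not repeat the earlier step, and the two instances disagree: the same change on two cores in this assay, a 2.9-fold lower number (0.47 log units; beyond the scatter) from compound 1 to compound 3 and a 1.1-fold higher number (0.04 log units; within the scatter) from compound 2 to compound 4, 3.2-fold (0.51 log units) apart, beyond the scatter of two such steps

This shows that the effect of this change in the series depends on the core that carries it, so the result from one core cannot simply be carried to another. Among the compounds shown here, with only two pairs, it does not show which difference between compound 1 and compound 2 accounts for the gap, or how the change would behave on any further core.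

The compounds shown leave open how an amine or a hydroxyl in place of that methoxy would compare with hydrogen on either core.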